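Trifluoromethyl for methyl on the benzyl sulfide arm

The source may report more compounds than this note shows. Statements on the series, on what has been measured and on what is new or still open speak of the compounds shown alone.

Of the compounds shown here, three sharing one core have been measured in a functional assay on HCT-116 cells (Homo sapiens) for cytotoxicity, read by MTT assay, with a stated time of 72 h; on this read-out higher numbers stand for weaker inhibition and lower numbers for stronger inhibition. Compound 1 `Cc1cccc(CSc2cc(Cl)c(C)cc2S(=O)(=O)/N=C(\N)n2nccc2-c2ccccc2)c1` gives 6500 nM. Within the data shown here, compound 3 `Cc1cc(S(=O)(=O)/N=C(\N)n2nccc2-c2ccccc2)c(SCc2cccc(Cl)c2)cc1Cl` gives 7000 nM, and the one change between them, a 1.1-fold higher number from compound 1 to compound 3 (0.03 log units; within the scatter), sits within the scatter. Compound 2 `Cc1ccc(CSc2cc(Cl)c(C)cc2S(=O)(=O)/N=C(\N)n2nc(C)cc2-c2ccccc2)cc1` gives 28000 nM, the highest of the three numbers; its values against compound 3 and compound 1 both lie beyond the scatter, though it differs from each of them in more than one place, so no single step accounts for the gap.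

Compound 4 `Cc1cc(-c2ccccc2)n(/C(N)=N/S(=O)(=O)c2cc(C)c(Cl)cc2SCc2ccc(C(F)(F)F)cc2)n1` is not yet measured. It differs from compound 2 in one place: trifluoromethyl in place of methyl on an aromatic carbon. Among the measured compounds shown here, no measured step exchanges methyl for trifluoromethyl; the only step of a similar kind, a different halogen-bearing group for methyl on the same arm, was within the scatter, and it concerned another position of that ring. On this basis the expected movement in this assay is small, with no direction that the data can support, and compound 4 is expected to stay near compound 2, with an expected step of a 1.1-fold lower number from compound 2 to compound 4 (0.05 log units; within the scatter). The estimate for compound 4 is 25000 nM, within a range from 8000 nM to 80000 nM.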

Compound 4, half-maximal inhibitory concentration: 7000 nM
The estimate for compound 4 lay 3.6-fold (0.55 log units) above the measured number, and the stated range ends above it.
By their numbers in this assay, from the lowest: compounds 1, 3 and 4 (each within the scatter of the next); then compound 2.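

Among these compounds, exchanging methyl for trifluoromethyl on the benzyl sulfide arm in this assay gives a 4.0-fold lower number from compound 2 to compound 4 (0.60 log units; beyond the scatter), the first single change that lies beyond the scatter. Among the compounds shown here, the only earlier single step, chloro in place of methyl at another position of that ring, gave a 1.1-fold higher number from compound 1 to compound 3 (0.03 log units; within the scatter), so it did not show that a substituent on this ring could move the number at all; this pair shows that it can when the group sits para to a large group, and that the number falls on going from 4-methylbenzyl to 4-(trifluoromethyl)benzyl. No measurement among the data bears on why this step has its size or direction.

On these data alone, whether the same exchange would move the number similarly on the core of compound 1, which differs from the core of compound 2 by one methyl on the five-membered part and in where its benzyl methyl sits, remains open, as this reading rests on a single pair. Also open, as far as these compounds go, is how other groups at this place, such as a nitrile, a methoxy group, an amine or a carboxylic acid, would compare with trifluoromethyl.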